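The source may report more compounds than this note shows. Statements on the series, on what has been measured and on what is new or still open speak of the compounds shown alone.

Measured so far in a physicochemical assay for solubility, with a stated time of 18 h, at pH 7.4; a higher number here means a more soluble compound, a lower number a less soluble compound: compound 1 `COc1ccc(F)cc1CNCCCNc1ccnc2cc(-c3ccccc3)ccc12` gives 32000 nM; compound 2 `Clc1ccc(Oc2ccc3c(NCCCNCc4ccco4)ccnc3c2)cc1` gives 14500 nM; compound 3 `COc1ccc(F)cc1CNCCCNc1ccnc2cc(CC3CCCCC3)ccc12` gives 4200 nM.

Compound 3 stands lowest of the three numbers, with compound 2 nearer to it and compound 1 furthest. Compound 4 `COc1ccc(F)cc1CNCCCNc1ccnc2cc(Oc3ccc(Cl)cc3)ccc12` is not yet measured; it differs from compound 3 as follows: 4-chlorophenoxy in place of cyclohexylmethyl on an aromatic carbon. Within the data shown here, one measured step bears on this: a 7.6-fold lower number from compound 1 to compound 3 (0.88 log units; beyond the scatter), where an aromatic group gave way to a saturated one. Compound 4 moves back to an aromatic group, and compound 2 carries the same 4-chlorophenoxy group on the shared core. Compound 4 is therefore expected to rise by a 2.9-fold higher number from compound 3 to compound 4 (0.46 log units; beyond the scatter). The estimate for compound 4 is 12000 nM, between 5000 nM and 30000 nM.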

Compound 4, solubility: 14500 nM
Compound 4: middle estimate off by 1.2-fold (0.08 log units), on the low side; the measured number falls inside the stated range.
By their numbers in this assay, from the lowest: compound 3; then compounds 2 and 4 (each within the scatter of the next); then compound 1.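

In this assay, the 4-chlorophenoxy group at this aromatic carbon gives a 3.5-fold higher number from compound 3 to compound 4 (0.54 log units; beyond the scatter), but against phenyl it gives a 2.2-fold lower number from compound 1 to compound 4 (0.34 log units; beyond the scatter), so the two groups with an aromatic ring also differ from each other. With 4-chlorophenoxy in place, 5-fluoro-2-methoxyphenyl in place of furan-2-yl on the saturated chain carbon gives no change at the digits printed from compound 2 to compound 4 (within the scatter). No measurement offered here explains these differences.

Going by these compounds, it remains open how an amine or a carboxylic acid at this aromatic carbon would compare. Whether the furan-2-yl swap would also leave the number unchanged with phenyl or cyclohexylmethyl at that carbon is open too.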